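This account rests on a few compounds, and the source may have more. Where it says the series, first, only, none or still open, it means among the compounds named here.

Measured compounds:
- compound 1 `N/N=C1\C(=O)Nc2ccc(S(=O)(=O)N3CCOCC3)cc21`: 46800 nM
- compound 2 `O=C1Nc2ccc(S(=O)(=O)N3CCOCC3)cc2/C1=N/c1ccc(C(=O)O)cc1`: 26700 nM
- compound 3 `CC(=O)c1cccc(/N=C2\C(=O)Nc3ccc(S(=O)(=O)N4CCOCC4)cc32)c1`: 39200 nM

In a functional assay on MCF7 cells (Homo sapiens) for cytotoxicity, read by sulforhodamine B assay, with a stated time of 24 h (on this read-out lower numbers stand for stronger inhibition and higher numbers for weaker inhibition), compound 1 gives the highest of the three numbers, but its gap to compound 3 a 1.2-fold lower number from compound 1 to compound 3 (0.08 log units; within the scatter) and to compound 2 a 1.8-fold lower number from compound 1 to compound 2 (0.24 log units; within the scatter) both stay within the scatter, so the three compounds cannot be told apart on these data. The step between compound 2 and compound 3 a 1.5-fold higher number from compound 2 to compound 3 (0.17 log units; within the scatter) is likewise within the scatter.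

Compound 4 `Cc1ccc(S(=O)(=O)N/N=C2\C(=O)Nc3ccc(S(=O)(=O)N4CCOCC4)cc32)cc1` has not yet been measured in this assay. It differs from compound 1 by (4-methylphenyl)sulfonyl in place of hydrogen on an amine nitrogen. Within the data shown here, none of the measured steps touches this amine nitrogen; the two steps from compound 1 instead swap the amino group on the double-bonded nitrogen for a substituted phenyl ring, and neither moves the number beyond the scatter. The closest guidance is therefore that sizeable additions near this end of the shared core have so far left the read-out essentially unchanged.

Compound 4 is accordingly expected to land close to compound 1, with the step of a 1.3-fold lower number from compound 1 to compound 4 (0.13 log units; within the scatter) expected to stay within the scatter. The estimate for compound 4 is 35000 nM, with a range from 12000 nM to 100000 nM.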

Compound 4, half-maximal inhibitory concentration: 38400 nM
Estimate against measurement, compound 4: 1.1-fold (0.04 log units) below, within the range that was stated.
By their numbers in this assay, from the lowest: compounds 2, 4, 3 and 1 (each within the scatter of the next).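

In this assay, putting (4-methylphenyl)sulfonyl in place of hydrogen on the amine nitrogen gives a 1.2-fold lower number from compound 1 to compound 4 (0.09 log units; within the scatter), so this first change at this nitrogen does not move the number beyond the scatter. The earlier steps shown here replaced the whole amino group with a substituted phenyl ring, whereas this one keeps the amine nitrogen, removes one of its hydrogens and adds 10 heavy atoms, including a six-membered aromatic ring, and the read-out still does not separate the two compounds. Nothing available bears on what lies behind this result.

On these data alone, what stays open is whether any group on this amine nitrogen can shift the number beyond the scatter, since a single substituent gives no trend: a small acetyl or methylsulfonyl group, or a sulfonyl group carrying a carboxylic acid or an amine on its phenyl ring in place of the methyl, could each behave differently. As far as these compounds go, it is also open whether this flat picture extends beyond this one cell line and this one exposure time, as every number here comes from this assay.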